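This account rests on a few compounds, and the source may have more. Where it says the series, first, only, none or still open, it means among the compounds named here.

Measured compounds: compound 1 `Cc1cc(O)c(C2=NN(c3ccc(S(N)(=O)=O)cc3)C(c3ccccc3Cl)C2)cc1Cl` with 33900 nM in a functional assay on TK-10 cells (Homo sapiens) for antiproliferative activity, with a stated time of 48 h; on this read-out lower numbers stand for higher toxicity in this test and higher numbers for lower toxicity in this test; compound 2 `Cc1cc(O)c(C2=NN(c3ccc(S(N)(=O)=O)cc3)C(/C=C/c3ccccc3)C2)cc1Cl` with 60700 nM.

Compound 2 holds the highest of the two numbers in this assay; its nearest neighbour differs from it by a 1.8-fold higher number from compound 1 to compound 2 (0.25 log units; within the scatter). Compound 3 `COc1ccc(C2CC(c3cc(Cl)c(C)cc3O)=NN2c2ccc(S(N)(=O)=O)cc2)cc1OC` differs from compound 2 by 3,4-dimethoxyphenyl in place of 2-phenylethenyl on a saturated ring carbon. For the measured compounds named here, only the step of a 1.8-fold higher number from compound 1 to compound 2 (0.25 log units; within the scatter) bears on this exchange on the same saturated ring carbon, and it stayed within the scatter. For compound 3 the expected step is a 1.4-fold lower number from compound 2 to compound 3 (0.16 log units; within the scatter), again within the scatter. Compound 3 is estimated at 42000 nM in this assay, with a range from 15000 nM to 110000 nM.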

Compound 3, concentration lethal to 50% of the cells: > 100000 nM
Compound 3: a limit, no number; the forecaster's own chance of this, stated with the estimate: 15%; at least 2.3-fold (0.37 log units) between middle value and limit.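

In this assay compound 3 gives only a limit, not a number: the limit of > 100000 nM in this assay, at which 1 of the 3 values shown sits. For the compounds shown here, for the first time an exchange on this saturated ring carbon reaches beyond the scatter, with an at least 2.9-fold higher number from compound 1 to compound 3 (0.46 log units; beyond the scatter), while the exchange of 2-phenylethenyl gives an at least 1.6-fold higher number from compound 2 to compound 3 (0.21 log units; that floor lies within the scatter). The group on this carbon can therefore shift the read-out towards lower toxicity in this test, though the full size of either step stays hidden behind the limit. Open, going by these compounds, is whether an amine or a carboxylic acid on this carbon would move the number, and whether a single methoxy group would do the same as two.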